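Chloro to methyl on the lowest compound so far

The source may report more compounds than this note shows. Statements on the series, on what has been measured and on what is new or still open speak of the compounds shown alone.

Values in a functional assay on DU-145 cells (Homo sapiens) for inhibition, read by MTT assay, with a stated time of 72 h (on this read-out higher numbers stand for weaker inhibition and lower numbers for stronger inhibition), for the measured compounds:
- compound 1 `O=C1C=C(N2CCN(c3ccc(F)cc3)CC2)C(=O)c2ccccc21` gives 11700 nM
- compound 2 `COc1ccc(N2CCN(C3=CC(=O)c4ccccc4C3=O)CC2)cc1` gives 46100 nM
- compound 3 `O=C1C=C(N2CCN(c3ccccc3Cl)CC2)C(=O)c2ccccc21` gives 2900 nM

Compound 3 stands lowest of the three at 2900 nM and its distance from each of the others lies beyond the scatter, with a 4.0-fold lower number from compound 1 to compound 3 (0.61 log units; beyond the scatter) and a 16-fold lower number from compound 2 to compound 3 (1.20 log units; beyond the scatter) as the two steps. The change from compound 3 to compound 4 `Cc1ccccc1N1CCN(C2=CC(=O)c3ccccc3C2=O)CC1` is methyl in place of chloro on an aromatic carbon, ortho to a large group, counted as methyl in place of chloro on an aromatic carbon and not yet measured.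

Within the data shown here, no measured step makes this swap. The nearest evidence is a 3.9-fold higher number from compound 1 to compound 2 (0.60 log units; beyond the scatter) for methoxy in place of fluoro on an aromatic carbon, a modest step beyond the scatter, while the two steps into compound 3 replace a whole substituted phenyl and say little here. In this assay, among the measured compounds shown here, no step beyond the scatter is therefore expected, with a lean to a higher number since compound 3 holds the lowest of only three values at 2900 nM so far. The estimated step is a 1.6-fold higher number from compound 3 to compound 4 (0.19 log units; within the scatter) and remains an expectation. Compound 4 is estimated at 4500 nM with an expected range from 1500 nM to 13000 nM until the measurement is in.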

Compound 4, half-maximal inhibitory concentration: 5700 nM
Compound 4: the middle estimate sits 1.3-fold (0.10 log units) below what was measured; low and high end bracket the measured number.
By their numbers in this assay, from the lowest: compounds 3 and 4 (each within the scatter of the next); then compound 1; then compound 2.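

In this assay, a 2.0-fold higher number from compound 3 to compound 4 (0.29 log units; within the scatter), so at this aromatic carbon, ortho to a large group, the read-out does not separate chloro from methyl. The low standing of compound 3 therefore does not rest on chloro alone: with 2-methylphenyl on the amine nitrogen there is still an 8.1-fold lower number from compound 2 to compound 4 (0.91 log units; beyond the scatter) against 4-methoxyphenyl, and a 2.1-fold lower number from compound 1 to compound 4 (0.31 log units; beyond the scatter) against 4-fluorophenyl, both beyond the scatter. Among these four compounds, the two with a 2-substituted phenyl give the lower numbers and none goes against that, though no evidence at hand bears on why chloro and methyl read alike here.

The steps from compound 1 and compound 2 change both the group and its place on the phenyl, so the compounds shown cannot tell which of the two matters, a question that 4-chlorophenyl and 4-methylphenyl partners would address. From the compounds shown here alone, it also stays open how far this position tolerates other groups, such as methoxy, trifluoromethyl or nitrile in the 2-position, or an amine or carboxylic acid there.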